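A few compounds are considered here, and "the series" means these few. Any claim that something is new, unique, unknown or untested is made for them only; others in the source may bear on it.

Compound 2, `COc1cc2cc(Oc3ccc(NC(=O)Nc4ccc(C)cc4)cc3)c(C)nc2cc1OC`, and compound 1, `COc1cc2cc(Oc3ccc(NC(=O)Nc4ccccc4)cc3)c(C)nc2cc1OC`, share one core and differ only in the group on an aromatic carbon of the outer phenyl ring. In a functional assay on CAKI-1 cells (Homo sapiens) for inhibition, read by sulforhodamine B assay, with a stated time of 48 h, tested at 10 uM (a higher number here means a weaker effect of the compound at the concentration tested, a lower number a stronger effect), compound 1 gives 88.7%, and compound 2 gives 98.2%. Compound 2 thus stands at the highest of the two numbers, but its nearest neighbour compound 1 lies within the scatter, so the two read as the same weak effect. Going by the values given here, the only step measured so far is a number 9.5 percentage points higher from compound 1 to compound 2 (within the scatter), and it shows no change beyond the scatter.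

Compound 3, `COc1cc2cc(Oc3ccc(NC(=O)Nc4ccc(C(F)(F)F)cc4)cc3)c(C)nc2cc1OC`, carries the next change on that same ring: trifluoromethyl in place of methyl on an aromatic carbon. Among the compounds with values here, this step touches the same place as the step from compound 1 to compound 2, which was within the scatter, and no other measured step bears on it. The author therefore expects compound 3 to move by about a number 10.2 percentage points lower from compound 2 to compound 3 (beyond the scatter) in this assay, with no change beyond the scatter and at most a modest downward drift. Compound 3 is estimated at 88%, in the range from 65% to 105%.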

Compound 3, a percentage reported as activity, at one concentration (the size of the read-out at that concentration, not a potency): 70.4%
Beside the measured number, compound 3's estimate is 17.6 percentage points above it, and the stated range covers the measured number.
By their numbers in this assay, from the lowest: compound 3; then compounds 1 and 2 (each within the scatter of the next).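

In this assay the exchange of methyl for trifluoromethyl gives a number 27.8 percentage points lower from compound 2 to compound 3 (beyond the scatter) and the exchange of hydrogen for trifluoromethyl gives a number 18.3 percentage points lower from compound 1 to compound 3 (beyond the scatter), so this position on the outer phenyl ring can move the read-out, which the step from hydrogen to methyl had not shown. With both steps beyond the scatter, compound 3 has the strongest effect of the three at the concentration tested, although each step is only modest and a single-concentration read-out says nothing about potency. The compounds shown offer no evidence on why trifluoromethyl separates from methyl and hydrogen here.

From the compounds shown here alone, it remains open whether this shift is particular to trifluoromethyl or would also appear with a chlorine, a nitrile or a methoxy group on the same aromatic carbon, and whether an amine or a carboxylic acid there would move the number in the same direction or the opposite one. Also open, going by these compounds, is whether trifluoromethyl would give a similar step at another carbon of this ring, or on a shared core altered elsewhere.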